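Alkoxy chain extension on the shared core of compound 1

This account rests on a few compounds, and the source may have more. Where it says the series, first, only, none or still open, it means among the compounds named here.

Measured so far:
compound 1 `CCCOc1c(-c2cc(OC)c(OC)c(OC)c2)oc2ccccc2c1=O`: 5700 nM
compound 2 `CCCCCOc1c(-c2cc(OC)c(OC)c(OC)c2)oc2ccccc2c1=O`: 15400 nM
compound 3 `CCN(CC)CCCCOc1c(-c2cc(OC)c(OC)c(OC)c2)oc2ccccc2c1=O`: 13500 nM

In a functional assay on LNCaP cells (Homo sapiens) for antiproliferative activity, read by WST assay, with a stated time of 3 days (on this read-out lower numbers stand for stronger inhibition and higher numbers for weaker inhibition), compound 1 gives the lowest number of the three, with compound 3 nearest and compound 2 furthest. Compound 4 `CCN(CC)CCCCCOc1c(-c2cc(OC)c(OC)c(OC)c2)oc2ccccc2c1=O` differs from compound 1 by 2-(diethylamino)ethyl in place of hydrogen on a saturated chain carbon, three bonds along the chain from an oxygen on an aromatic ring. Among the measured compounds shown here, two measured steps bear on this: a 2.7-fold higher number from compound 1 to compound 2 (0.43 log units; beyond the scatter) and a 2.4-fold higher number from compound 1 to compound 3 (0.37 log units; beyond the scatter), both modest and both pointing the same way, while a 1.1-fold lower number from compound 2 to compound 3 (0.06 log units; within the scatter) stays within the scatter. The change to compound 4 lengthens the chain further than either, so a step of comparable or slightly larger size, toward a higher number, is expected: a 3.0-fold higher number from compound 1 to compound 4 (0.47 log units; beyond the scatter). For compound 4 the estimate is 17000 nM, with a range from 7500 nM to 40000 nM.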

Compound 4, half-maximal inhibitory concentration: 10000 nM
Estimate against measurement, compound 4: 1.7-fold (0.23 log units) above, and the stated range covers the measured number.
By their numbers in this assay, from the lowest: compounds 1, 4, 3 and 2 (each within the scatter of the next, the first and the last beyond it).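

With the 5-(diethylamino)pentyl chain in this assay, the separation from the propyl ether of compound 1 no longer exceeds the scatter, at a 1.8-fold higher number from compound 1 to compound 4 (0.24 log units; within the scatter) here. Compound 4 also stays within the scatter of the two other chains, with a 1.4-fold lower number from compound 3 to compound 4 (0.13 log units; within the scatter) and a 1.5-fold lower number from compound 2 to compound 4 (0.19 log units; within the scatter) as the readings, so neither change gives a readable shift. No evidence at hand accounts for these results.

Open, as far as these compounds go, is whether a dimethylamino group, a piperidine or a carboxylic acid on the chain would separate from compound 1.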